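The source may hold more compounds than are shown below. What is called first, only, known or untested is meant among the compounds shown, and "the series" means these compounds.

Compound 1 `Fc1ccc(Nc2ccc3c(C4CCNCC4)c[nH]c3c2)cc1F`: 85%
Compound 2 `Cn1cc(C2CCNCC2)c2ccc(Nc3ccc(F)c(F)c3)cc21`: 83%

In an ADME assay on microsomes from liver (Mus musculus) for metabolic stability, with a stated time of 1 h (a lower number here means that less of the compound is left, a higher number that more of the compound is left), compound 1 gives 85% and compound 2 gives 83%, two numbers within the scatter of each other, so neither stands apart. Compound 3 `CN1CCC(c2c[nH]c3cc(Nc4ccc(F)c(F)c4)ccc23)CC1` has not yet been measured. Its structure differs from that of compound 1 in one place: methyl in place of hydrogen on an amine nitrogen in a ring, in short, methyl in place of hydrogen on an amine nitrogen in a ring.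

Among the compounds with values here, only one measured step offers a comparison. That step, a number 2 percentage points lower from compound 1 to compound 2 (within the scatter), also puts methyl in place of hydrogen, but on an aromatic nitrogen, so it is a loose guide at best. Within the data shown here, no step at the amine nitrogen has been measured. On this thin evidence, no change beyond the scatter is expected in this assay, although a drop cannot be ruled out, and the range is therefore set wider downward than upward. The expected change is a number 7 percentage points lower from compound 1 to compound 3 (within the scatter) as an estimate. For compound 3 the estimated value is 78%, with an expected range from 50% to 93%.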

Compound 3, percent of the compound remaining: 35%
For compound 3 the middle estimate is 43 percentage points above the measured one, and the stated range ends above it.
By their numbers in this assay, from the lowest: compound 3; then compounds 2 and 1 (each within the scatter of the next).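

In this assay, the amine nitrogen of the piperidin-4-yl group proves to be a sensitive position: going to 1-methylpiperidin-4-yl gives a number 50 percentage points lower from compound 1 to compound 3 (beyond the scatter), so this single added carbon is enough to change the result sharply. The same replacement of hydrogen by methyl on the aromatic nitrogen gives only a number 2 percentage points lower from compound 1 to compound 2 (within the scatter), so in these compounds the effect of a methyl depends strongly on which nitrogen carries it, a contrast that neither compound 1 nor compound 2 could show without compound 3. Nothing available here explains why the step at the amine nitrogen is so large.

The compounds shown leave open whether the low number belongs to methyl alone or extends to other groups on the same amine nitrogen, such as an ethyl group, a longer chain or an acetyl group. They also leave open whether this large step would recur on a core carrying different substituents, since it rests on a single pair of compounds.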